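The source may report more compounds than this note shows. Statements on the series, on what has been measured and on what is new or still open speak of the compounds shown alone.

Compound 1, `CNC(=O)c1cc(C(=O)NC2CC2)cc2c1OC[C@@]2(C)c1ccccc1`: >= 138 ug/mL
Compound 2, `CNC(=O)c1cc(C(=O)NC)c2c(c1)[C@](C)(c1ccccc1)CO2`: >= 132 ug/mL
Compound 3, `CNC(=O)c1cc(C(=O)NC)c2c(c1)[C@H](c1ccccc1)[C@@H](CF)O2`: >= 149 ug/mL

Each of these three values is a limit of the assay rather than a measured number. In a physicochemical assay for solubility (on this read-out higher numbers stand for higher solubility and lower numbers for lower solubility), compound 1 reaches >= 138 ug/mL, a limit. Compound 2 reaches >= 132 ug/mL, likewise a limit. Compound 3 reaches >= 149 ug/mL, again a limit.

Compounds 1 and 2 share one core and differ in a single place: cyclopropyl in place of methyl on an amide-type nitrogen. The step that the two limits leave unreadable from compound 2 to compound 1 cannot be read because the limit of >= 138 ug/mL in this assay, at which 1 of the 3 values shown sits, and the limit of >= 132 ug/mL in this assay, at which 1 of the 3 values shown sits, are both ends of it, so nothing is learned about whether this change moves solubility at all.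

Compound 3 carries a different core; how it differs from compound 2 is not broken down here. Compound 4, `CNC(=O)c1cc(C(=O)NC2CC2)cc2c1O[C@H](CF)[C@H]2c1ccccc1`, is not yet measured and stands to compound 3 exactly as compound 1 stands to compound 2: cyclopropyl in place of methyl on an amide-type nitrogen. The place is worded the same in both cases, so this is the same change, repeated on a second core.

The earlier step is unreadable. The expectation rests on where the measured compounds sit rather than on a measured effect. Because compound 3 sits at the limit of >= 149 ug/mL in this assay, at which 1 of the 3 values shown sits, and its two companions also sit at limits, compound 4 is expected to show a step of about an at least 1.0-fold lower number from compound 3 to compound 4 (0.02 log units; that floor lies within the scatter), landing near 140 ug/mL, within the span from 60 ug/mL to 220 ug/mL, most likely again reported only as a limit.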

Compound 4, solubility: 8 ug/mL
Beside the measured number, compound 4's estimate is 18-fold (1.24 log units) above it; the whole stated range lies above it.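

In this assay, putting cyclopropyl in place of methyl on an amide-type nitrogen gives an at least 18-fold lower number from compound 3 to compound 4 (1.27 log units; beyond the scatter), so on the core of compound 3 this small change comes with a large fall, and the true fall may be larger still because the starting value is only a limit: the limit of >= 149 ug/mL in this assay, at which 1 of the 4 values shown sits. The same change from compound 2 to compound 1 cannot be read, as both ends of that step are limits of the assay and not numbers. Among these compounds, the series therefore does not show that the change acts differently on the two cores, nor that it acts alike, since a fall could be hidden behind those limits on the core of compound 1, and the single readable pair gives no measured reason for the fall on the core of compound 3.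

As far as these compounds go, what stays open is whether the fall belongs to cyclopropyl in particular or would also come with another group on the same nitrogen, such as ethyl, or a longer chain ending in an amine or a carboxylic acid. From the compounds shown here alone, it is also open how far the values of compound 1, compound 2 and compound 3 actually lie beyond their limits, and only numbers at those ends could settle the comparison between cores.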